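Swapping the Amide Substituent in a Weakly Cytotoxic Series

The source may report more compounds than this note shows. Statements on the series, on what has been measured and on what is new or still open speak of the compounds shown alone.

Of the compounds shown here, three sharing one core have been tested in an ADME assay on SW480 cells (Homo sapiens) for cytotoxicity, read by MTT assay, with a stated time of 72 h; a higher number here means a weaker inhibitor, a lower number a stronger inhibitor. Compound 1, `CCOc1ccc(NC(=O)c2cccc(/C=C3\CC(=O)N(Cc4ccccc4)C3=O)c2)cc1`, gives 73200 nM. Compound 2, `COc1ccc(NC(=O)c2cccc(/C=C3\CC(=O)N(c4ccc(C)cc4)C3=O)c2)cc1`, gives 93000 nM. Compound 3, `COc1ccc(OC)c(NC(=O)c2cccc(/C=C3\CC(=O)N(c4ccccc4)C3=O)c2)c1`, reaches only a limit of this assay, > 100000 nM, so no number is known for it. Compound 3 stands at the limit of > 100000 nM in this assay, at which 1 of the 3 values shown sits.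

Compound 4, `O=C(NCc1ccccc1)c1cccc(/C=C2\CC(=O)N(c3ccccc3)C2=O)c1`, has not yet been measured. It differs from compound 3 in one place: benzyl in place of 2,5-dimethoxyphenyl on an amide-type nitrogen. Within the data shown here, no measured pair differs in exactly this way, so the size of the step cannot be read from any neighbour. Compound 1 with 73200 nM and compound 2 with 93000 nM both lie high in this assay, and all three measured compounds are weak inhibitors in this assay. The step from compound 3 to compound 4 is expected to be small, an at least 1.1-fold lower number from compound 3 to compound 4 (0.04 log units; that floor lies within the scatter), no further than the usual scatter in either direction. Compound 4 is therefore estimated at 90000 nM, with a likely range from 40000 nM to 200000 nM, and a fair chance that only a limit is reported once more.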

Compound 4, half-maximal inhibitory concentration: > 100000 nM
Compound 4: no number, only a limit; the forecaster's own chance of this, stated with the estimate: 40%; at least 1.1-fold (0.04 log units) between middle value and limit.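

Compound 3 and compound 4 each reach only a limit in this assay, so the step between them cannot be read: the limit of > 100000 nM in this assay, at which 2 of the 4 values shown sit.

The compounds shown leave open where the true values of compound 3 and compound 4 lie, and whether benzyl in place of 2,5-dimethoxyphenyl changes the result at all.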